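This account rests on a few compounds, and the source may have more. Where it says the series, first, only, none or still open, it means among the compounds named here.

Measured so far in an in vitro ADME assay on microsomes from liver (Homo sapiens) for metabolic stability, tested at 1 uM; on this read-out lower numbers stand for a shorter-lived compound and higher numbers for a longer-lived compound:
Compound 1 `Cc1cc(/C=C/C#N)cc(C)c1Oc1cc(Nc2ccc(C#N)cc2)c(N)cc1[N+](=O)[O-]`: 0.797 h
Compound 2 `Cc1cc(CCC#N)cc(C)c1Oc1cc(Nc2ccc(C#N)cc2)c(N)cc1C(F)(F)F`: 0.928 h

Compound 1 stands level with compound 2 on these numbers. Their two half-lives lie within the usual scatter of repeated measurements, so neither can be called the longer-lived.

Still unmeasured is compound 3 `COC(=O)c1cc(N)c(Nc2ccc(C#N)cc2)cc1Oc1c(C)cc(/C=C/C#N)cc1C`, which keeps the core of compound 1 and changes a single group: methoxycarbonyl in place of nitro on an aromatic carbon. This group sits para to a (4-cyanophenyl)amino group and meta to an amino group.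

Going by the values given here, the two measured compounds differ in more than one place, so no measured step shows what this swap does. The best anchor is compound 1 itself, at 0.797 h. In this assay, no step beyond the scatter is expected, with only a slight lean towards lower numbers. The estimated change is a 1.3-fold lower number from compound 1 to compound 3 (0.12 log units; within the scatter). For compound 3, the expected half-life is 0.6 h, with an estimated range of 0.2 h to 1.4 h.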

Compound 3, half-life: 4.72 h
Compound 3: the middle estimate sits 7.9-fold (0.90 log units) below what was measured; the measured number lies above the stated range.
By their numbers in this assay, from the lowest: compounds 1 and 2 (each within the scatter of the next); then compound 3.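

In this assay, placing methoxycarbonyl instead of nitro on this aromatic carbon, which is para to a (4-cyanophenyl)amino group and meta to an amino group, gives a 5.9-fold higher number from compound 1 to compound 3 (0.77 log units; beyond the scatter) with the rest of compound 1 unchanged. Compounds 1 and 2 differ in more than one place, so they could not isolate this position; this pair shows that a change here alone can move the half-life by more than the usual scatter, even though the two groups differ by only one heavy atom and have the same counts of hydrogen-bond donors and acceptors. No measurement shown here gives the reason for the step.

Compound 2 carries trifluoromethyl on the matching carbon but also differs elsewhere, so what each group does at this position on an otherwise identical compound stays unresolved. Going by these compounds, it also remains open whether ethoxycarbonyl, a carboxylic acid or a primary amide on this carbon would give a half-life closer to compound 3 or to compound 1, and whether the step would hold with a different chain on the other ring.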